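The compounds below may be only part of what the source reports. "The series", "measured", "known", "first", "only" and "open" are said of these compounds alone.

Values in a functional assay on HeLa cells (Homo sapiens) for cytotoxicity, read by MTT assay, with stated times of 3 h and 24 h; on this read-out lower numbers stand for stronger inhibition and higher numbers for weaker inhibition:
- compound 1 `COc1ccc(C2=[N+]3C(=Nc4c(-c5ccccc5)c5c(n4[B-]3(F)F)-c3ccc(OC)cc3CC5)C(c3ccccc3)=C2Br)cc1`: 830 nM
- compound 2 `COc1ccc2c(c1)CCc1c(-c3ccccc3)c3n(c1-2)[B-](F)(F)[N+]1=C(c2ccc(C)cc2)C(Br)=C(c2ccccc2)C1=N3`: 1200 nM

Compound 2 stands at 1200 nM, within the scatter of compound 1, so this assay does not separate these two compounds. The next compound to consider is compound 3 `COc1ccc2c(c1)CCc1c(-c3ccccc3)c3n(c1-2)[B-](F)(F)[N+]1=C(c2ccc(C)s2)C(Br)=C(c2ccccc2)C1=N3`. Its difference from compound 2 is 5-methylthiophen-2-yl in place of 4-methylphenyl on a carbon with a double bond to nitrogen.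

Going by the values given here, only one measured step bears on this change: a 1.4-fold higher number from compound 1 to compound 2 (0.16 log units; within the scatter), with methyl in place of methoxy on an aromatic carbon. That step alters the substituent on the aromatic ring that leaves in compound 3, but not the ring itself. Among the compounds with values here, no measured compound carries a five-membered aromatic ring with 1 hetero atom at this place, so the data offer no direct precedent and no basis for a direction. No step beyond the scatter is therefore expected, and the estimate stays close to the two measured values.

The expected step is a 1.2-fold lower number from compound 2 to compound 3 (0.08 log units; within the scatter). For compound 3 the estimated value is 1000 nM, with an expected range of 450 nM to 2300 nM.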

Compound 3, half-maximal inhibitory concentration: 22600 nM
Estimate against measurement, compound 3: 23-fold (1.35 log units) below, and the stated range ends below it.
By their numbers in this assay, from the lowest: compounds 1 and 2 (each within the scatter of the next); then compound 3.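

In this assay, the identity of the ring on the carbon with a double bond to nitrogen proves decisive where its substituent did not: changing 4-methoxyphenyl to 4-methylphenyl stayed within the scatter (a 1.4-fold higher number from compound 1 to compound 2 (0.16 log units; within the scatter)), whereas 5-methylthiophen-2-yl in place of 4-methylphenyl gives a large loss of inhibition (a 19-fold higher number from compound 2 to compound 3 (1.27 log units; beyond the scatter)). The same loss appears against the methoxy-bearing ring (a 27-fold higher number from compound 1 to compound 3 (1.44 log units; beyond the scatter)), so within these three compounds both six-membered aromatic rings at this place read far stronger than the five-membered aromatic ring with its sulfur atom. No measurement on these compounds explains the size of this step.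

The compounds shown leave open whether the loss belongs to the thiophene ring itself, to the methyl group on it, or to five-membered aromatic rings at this place more widely, which unsubstituted thiophen-2-yl and furan-2-yl would help to separate. Also open, going by these compounds, is how far the six-membered ring tolerates other substituents in place of methyl or methoxy, such as an amine or a carboxylic acid.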